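The source may report more compounds than this note shows. Statements on the series, on what has been measured and on what is new or still open speak of the compounds shown alone.

Measured in a functional assay (aorta) with Oryctolagus cuniculus as the target; on this read-out lower numbers stand for tighter binding and higher numbers for weaker binding:
- compound 1 `Oc1c(Cl)cc(Cn2c(C3CC3)nc3cccnc32)cc1Cl`: 20 nM
- compound 2 `Cc1ccnc2c1nc(C1CC1)n2Cc1cc(Cl)c(O)c(Cl)c1`: 2 nM
- compound 3 `Cc1ccnc2c1nc(C)n2Cc1ccc(-c2ccccc2C(=O)O)cc1`: 50.1 nM

Compound 3 has the highest of these three numbers. Compound 4 `CCSc1nc2c(C)ccnc2n1Cc1ccc(-c2ccccc2C(=O)O)cc1` carries ethylsulfanyl in place of methyl on an aromatic carbon.

For the measured compounds named here, the only measured step is a 10-fold lower number from compound 1 to compound 2 (1.00 log units; beyond the scatter). It is a swap of methyl for hydrogen, and it lies elsewhere in the molecule: compound 3 and compound 4 both keep that methyl. It therefore says nothing directly about the size of the new change. The nearest hint is compound 2 at 2 nM, which has cyclopropyl rather than methyl on this carbon, though its large group also differs from that of compound 3. The expectation is thus only a modest move towards a lower number, held with wide uncertainty.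

The estimated change is a 4.2-fold lower number from compound 3 to compound 4 (0.62 log units; beyond the scatter). For compound 4 the expected value is 12 nM, with an estimated range of 2 nM to 70 nM.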

Compound 4, dissociation constant: 5.01 nM
The estimate for compound 4 lay 2.4-fold (0.38 log units) above the measured number; the range from low to high includes it.
By their numbers in this assay, from the lowest: compound 2; then compound 4; then compound 1; then compound 3.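

In this assay, the aromatic carbon between two ring nitrogen atoms accepts a group larger than methyl, and ethylsulfanyl in place of methyl gives (a 10-fold lower number from compound 3 to compound 4 (1.00 log units; beyond the scatter)). For the compounds shown here, this is the first measured step at this position, and it matches in size the only earlier step (a 10-fold lower number from compound 1 to compound 2 (1.00 log units; beyond the scatter)), which lay elsewhere in the molecule. The data offer nothing that bears on why the number falls at this carbon.

The compounds shown cannot separate the part played by the sulfur from that of the ethyl chain, which a propyl, ethoxy or ethylamino group on this carbon would help to resolve. Going by these compounds, it also remains open whether a longer thioether, such as propylsulfanyl, would move the number further.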